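The source may hold more compounds than are shown below. What is called first, only, known or untested is meant among the compounds shown, and "the series" means these compounds.

Of the compounds shown here, two on the shared core have numbers so far in a functional assay on MDA-MB-231 cells (Homo sapiens) for inhibition, read by MTT assay, with a stated time of 48 h; a higher number here means a weaker inhibitor of growth, a lower number a stronger inhibitor of growth. Compound 1 `S=C(Nc1ccccc1)Nc1ccc2ncnc(Nc3cccc(Br)c3)c2c1` gives 10000 nM. Compound 2 `FC(F)(F)c1ccc(NC(=S)Nc2ccc3ncnc(Nc4cccc(Br)c4)c3c2)cc1` gives 12200 nM, which places compound 2 within the scatter of compound 1, so the two cannot be separated. Going by the values given here, the only measured step is a 1.2-fold higher number from compound 1 to compound 2 (0.09 log units; within the scatter), for trifluoromethyl in place of hydrogen on an aromatic carbon.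

Next in the series is compound 3 `FC(F)(F)c1cccc(NC(=S)Nc2ccc3ncnc(Nc4cccc(Br)c4)c3c2)c1`, which has the same atoms as compound 2, joined differently: 3-(trifluoromethyl)phenyl in place of 4-(trifluoromethyl)phenyl on an amide-type nitrogen. In words, this is 3-(trifluoromethyl)phenyl in place of 4-(trifluoromethyl)phenyl on an amide-type nitrogen. Among the compounds with values here, no measured pair tests this kind of change directly, so the evidence is indirect. Within the data shown here, the one step that bears on it, a 1.2-fold higher number from compound 1 to compound 2 (0.09 log units; within the scatter), shows that putting the trifluoromethyl group on this ring left the number within the scatter. No step beyond the scatter is therefore expected in this assay, and neither direction is favoured.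

For compound 3 the estimated value is 10000 nM, with an expected range of 4500 nM to 22000 nM. The expected change is a 1.2-fold lower number from compound 2 to compound 3 (0.09 log units; within the scatter).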

Compound 3, concentration for 50% growth inhibition: 1400 nM
Beside the measured number, compound 3's estimate is 7.1-fold (0.85 log units) above it, outside the stated range (below it).
By their numbers in this assay, from the lowest: compound 3; then compounds 1 and 2 (each within the scatter of the next).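

In this assay, the placing of the trifluoromethyl group on the phenyl ring now proves to matter: 3-(trifluoromethyl)phenyl in place of 4-(trifluoromethyl)phenyl on the amide-type nitrogen gives an 8.7-fold lower number from compound 2 to compound 3 (0.94 log units; beyond the scatter) and so separates two compounds with the same atoms. The earlier reading, that trifluoromethyl on this ring changes nothing that can be resolved, therefore holds only for 4-(trifluoromethyl)phenyl, with a 1.2-fold higher number from compound 1 to compound 2 (0.09 log units; within the scatter) for that change, whereas 3-(trifluoromethyl)phenyl gives a 7.1-fold lower number from compound 1 to compound 3 (0.85 log units; beyond the scatter) as the same kind of replacement of hydrogen. No measurement at hand gives a reason for this difference between the two placements.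

The compounds shown leave open whether the lower number is particular to trifluoromethyl or would also appear with a nitrile, a methoxy group or a chlorine in the place that trifluoromethyl holds in compound 3. They also leave open whether the 3-(trifluoromethyl)phenyl gain survives when a carbonyl replaces the thiocarbonyl on the linking carbon.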